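The compounds below may be only part of what the source reports. "The series", "measured", "known", "first", "only" and "open" are said of these compounds alone.

- compound 1 `CN(C)C(=O)c1cc2cnc(Nc3ccc(NC(=O)C4(C(=O)Nc5ccc(F)cc5)CC4)cc3)nc2n1C1CCCC1`: 102%
- compound 2 `CN(C)C(=O)c1cc2cnc(Nc3ccc(NC(=O)C4(C(=O)Nc5ccccc5F)CC4)cc3)nc2n1C1CCCC1`: 93.1%
- compound 3 `CN(C)C(=O)c1cc2cnc(Nc3ccc(NC(=O)C4(C(=O)Nc5ccc(Cl)c(C(F)(F)F)c5)CC4)cc3)nc2n1C1CCCC1`: 91.9%

These three compounds share one core and differ only in the aromatic ring on an amide-type nitrogen. In a functional assay on NCI-H460 cells (Homo sapiens) for inhibition, read by CCK-8 assay, with a stated time of 72 h, tested at 10 uM (a lower number here means less inhibition of growth, a higher number more inhibition of growth at the concentration tested), compound 3 gives 91.9%. That value lies within the scatter of compound 2 but beyond the scatter of compound 1.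

The next compound is compound 4 `CN(C)C(=O)c1cc2cnc(Nc3ccc(NC(=O)C4(C(=O)Nc5ccccc5)CC4)cc3)nc2n1C1CCCC1`, which has phenyl in place of 4-chloro-3-(trifluoromethyl)phenyl on an amide-type nitrogen. Going by the values given here, no measured step makes this exact swap, but two involve the same group at the same place. One is a number 10.1 percentage points lower from compound 1 to compound 3 (beyond the scatter), which is only just past the scatter. The other is a number 1.2 percentage points lower from compound 2 to compound 3 (within the scatter). Read in reverse, they suggest that losing this group could raise the number slightly or leave it unchanged. In this assay, no step beyond the scatter is therefore expected. The estimate means an expected a number 3.1 percentage points higher from compound 3 to compound 4 (within the scatter). For compound 4, the estimated value is 95%, with an expected range of 84% to 105%.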

Compound 4, percent growth inhibition at one concentration: 95.9%
Beside the measured number, compound 4's estimate is 0.9 percentage points below it; measured number inside the range.
By their numbers in this assay, from the lowest: compounds 3, 2, 4 and 1 (each within the scatter of the next, the first and the last beyond it).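

In this assay, the plain phenyl ring of compound 4 cannot be told apart from any of the substituted rings: the steps read a number 4 percentage points higher from compound 3 to compound 4 (within the scatter), a number 2.8 percentage points higher from compound 2 to compound 4 (within the scatter) and a number 6.1 percentage points lower from compound 1 to compound 4 (within the scatter). Going by these compounds alone, at this position on the amide-type nitrogen, neither fluoro nor the chloro and trifluoromethyl pair is therefore needed to keep this level of growth inhibition at the concentration tested, and compound 4 lies within the scatter of both compounds in the one pair that stands beyond it. No measurement shown here explains this result.

The compounds shown leave open whether a methoxy group or an amine on this ring, or a cyclohexyl group in place of the phenyl, would keep this inhibition. They also leave open whether these four compounds would separate at a lower concentration.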